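The source may report more compounds than this note shows. Statements on the series, on what has been measured and on what is new or still open speak of the compounds shown alone.

Working notes on the aminothiazole series

The shared core of compound 1 `FC(F)(F)c1ccccc1Nc1nc(-c2ccncc2)cs1` carries an aniline with a trifluoromethyl group. In a functional assay on RCC4 cells (Homo sapiens) for inhibition, read by XTT assay, with a stated time of 4 days (on this read-out lower numbers stand for stronger inhibition and higher numbers for weaker inhibition), compound 1 gives 40700 nM. Compound 2 `COc1ccccc1Nc1nc(-c2ccncc2)cs1` differs from compound 1 by methoxy in place of trifluoromethyl on an aromatic carbon; in this assay compound 2 gives 33900 nM, so the step of a 1.2-fold lower number from compound 1 to compound 2 (0.08 log units; within the scatter) is small and lies within the usual scatter. Compound 3 `FC(F)(F)c1ccc(Nc2nc(-c3ccncc3)cs2)cc1` has the same atoms as compound 1 joined differently; how the two cores differ is not broken down here. In this assay compound 3 gives 40700 nM, level with compound 1 at the digits recorded and, with it, at the high end of the three numbers recorded so far.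

Compound 4 `COc1ccc(Nc2nc(-c3ccncc3)cs2)cc1` has not yet been measured in this assay. It differs from compound 3 by methoxy in place of trifluoromethyl on an aromatic carbon. Among the measured compounds shown here, this is the same kind of change as the one from compound 1 to compound 2, but not the same: in the earlier pair the group sits ortho to a large group, whereas here it sits para to a large group. For the measured compounds named here, only one such step has been measured, so the expectation rests on a single pair.

The step from compound 3 to compound 4 is expected to be about a 1.2-fold lower number from compound 3 to compound 4 (0.08 log units; within the scatter), because the earlier step of a 1.2-fold lower number from compound 1 to compound 2 (0.08 log units; within the scatter) was small. Compound 4 is therefore estimated at 34000 nM in this assay, with a range of 15000 nM to 80000 nM.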

Compound 4, half-maximal inhibitory concentration: 14100 nM
Estimate against measurement, compound 4: 2.4-fold (0.38 log units) above; measured number outside the range, below it.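

The same change, methoxy in place of trifluoromethyl, now para to a large group on an aromatic carbon, gives in this assay a 2.9-fold lower number from compound 3 to compound 4 (0.46 log units; beyond the scatter), a modest step that brings compound 4 to 14100 nM. Set beside the earlier step on the other core, the new step does not differ from it by more than such steps scatter: the same change on two cores in this assay, a 1.2-fold lower number (0.08 log units; within the scatter) from compound 1 to compound 2 and a 2.9-fold lower number (0.46 log units; beyond the scatter) from compound 3 to compound 4, 2.4-fold (0.38 log units) apart, within the scatter of two such steps. The two cores therefore give no ground for saying that this change behaves differently from one to the other, but two steps, only one of them beyond the scatter, do not establish that its size carries over, and they cannot separate an effect of the core from an effect of where the group sits.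

The compounds shown leave open whether a step of this kind would recur on further cores of the series, and whether it would hold in any read-out other than this assay. They also leave open what happens when an amine, a carboxylic acid or a longer chain such as ethoxy takes the place of methoxy or trifluoromethyl on the aromatic ring.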